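Notes on a hydrazone series: from compound 1 to compound 3

The compounds below may be only part of what the source reports. "The series", "measured", "known", "first", "only" and "open" are said of these compounds alone.

Compound 1 `CN(C)CCn1cnnc1-c1cc(Oc2ccc(NC(=O)N/N=C/c3c(O)ccc4ccccc34)cc2F)ccn1` is the reference point of this small set. For the measured compounds named here, in a functional assay on A549 cells (Homo sapiens) for cytotoxicity, read by MTT assay, with a stated time of 72 h (a lower number here means a stronger inhibitor, a higher number a weaker inhibitor), compound 1 gives 880 nM, the lowest of the two numbers measured so far. Compound 2 `Cn1cnnc1-c1cc(Oc2ccc(NC(=O)N/N=C/c3ccccc3)cc2F)ccn1` gives in this assay a value of 7560 nM, a gap from compound 1 that lies beyond the scatter. Compound 3 `COc1cc(/C=N/NC(=O)Nc2ccc(Oc3ccnc(-c4nncn4CCN(C)C)c3)c(F)c2)ccc1O` has not yet been measured. Going by the values given here, it differs from compound 1 in one place: 4-hydroxy-3-methoxyphenyl in place of 2-hydroxynaphthalen-1-yl on a carbon with a double bond to nitrogen No measured pair in the set shows a change of this kind, so the expectation rests on the structural change alone and carries wide uncertainty. The expected step is a 2.0-fold higher number from compound 1 to compound 3 (0.31 log units; beyond the scatter), a weakening of inhibition that is expected to exceed the scatter only slightly. For compound 3 the estimated value in this assay is 1800 nM, with a range expected from 600 nM to 5000 nM.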

Compound 3, half-maximal inhibitory concentration: > 100000 nM
Compound 3 was reported as a limit (the forecaster's own chance of this, stated with the estimate: 5%); middle value at least 55-fold (1.74 log units) away from the limit.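

In this assay, the carbon with a double bond to nitrogen proves to be a highly sensitive place: 4-hydroxy-3-methoxyphenyl in place of 2-hydroxynaphthalen-1-yl gives an at least 110-fold higher number from compound 1 to compound 3 (2.05 log units; beyond the scatter), with the rest of compound 1 unchanged. For the compounds shown here, this is the first comparison in the set that differs in one place, so this sensitivity could not be read from the earlier compounds. Compound 3 is reported only as a limit, so the step gives a bound and not an exact size: the limit of > 100000 nM in this assay, at which 1 of the 3 values shown sits.

The compounds shown leave open whether the second aromatic ring, the methoxy group or the position of the hydroxy group decides the outcome, as all three change in this one step. A plain naphthalen-1-yl or a 2-hydroxyphenyl on this carbon would help separate these contributions.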